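This account rests on a few compounds, and the source may have more. Where it says the series, first, only, none or still open, it means among the compounds named here.

Compound 1, `CCOC(=O)c1ccc(NC(=O)N2CC2C#N)cc1`: in a functional assay on A549 cells (Homo sapiens) for inhibition (on this read-out higher numbers stand for weaker inhibition and lower numbers for stronger inhibition), compound 1 gives 2900 nM.
Compound 2, `N#CC1CN1C(=O)Nc1ccc(Cl)cc1Cl`: in this assay compound 2 gives 2500 nM.
Compound 3, `N#CC1CN1C(=O)NC1CCCCC1`: in this assay compound 3 gives 10000 nM.

Three compounds share the same core, a small nitrile-bearing ring joined through a urea to a varying side. Compound 1 has the second highest number of the three. Its nearest neighbour is compound 2, whose number lies within the usual scatter of compound 1, so the two cannot be told apart on these data. Compound 3, which carries a saturated ring in place of an aromatic one, stands furthest away, with a higher number that lies beyond the scatter and therefore marks clearly weaker inhibition.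

The next compound, compound 4, `N#CC1CN1C(=O)Nc1ccc(F)cc1`, keeps the aromatic ring of compound 1 and changes one group on it: fluoro in place of ethoxycarbonyl on an aromatic carbon. Among the measured compounds shown here, no measured pair shows this exact change, so its effect can only be guessed. Because compound 2, which also bears halogen on the aromatic ring, gives 2500 nM, the expectation is a small step in this assay, at most a modest move toward weaker inhibition, possibly none beyond the scatter. The expected step is a 1.4-fold higher number from compound 1 to compound 4 (0.14 log units; within the scatter). Compound 4 is estimated at 4000 nM, with a likely range from 1500 nM to 12000 nM.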

Compound 4, half-maximal inhibitory concentration: 6200 nM
Compound 4: middle estimate off by 1.6-fold (0.19 log units), on the low side, and the stated range covers the measured number.
By their numbers in this assay, from the lowest: compounds 2 and 1 (each within the scatter of the next); then compounds 4 and 3 (each within the scatter of the next).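

Among the compounds shown here, replacing ethoxycarbonyl with fluoro on the aromatic carbon, para to a group of 8 heavy atoms, gives the first comparison in this set in which only one place changes, and in this assay it brings a 2.1-fold higher number from compound 1 to compound 4 (0.33 log units; beyond the scatter) and so weaker inhibition. The step is modest, yet it lies beyond the usual scatter, so what sits at this position does affect the read-out, and this particular swap costs some inhibition. No supporting measurement accompanies this step, so it cannot be tied to any particular property of either group.

A single swap cannot show whether the ethoxycarbonyl group helps inhibition or the fluoro group hinders it, since the two groups differ in several ways at once. The compounds shown also leave open how a carboxylic acid, an amine or a longer chain at this same aromatic carbon would compare, and those would show whether the read-out follows any trend at this position.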